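The source may hold more compounds than are shown below. What is called first, only, known or untested is meant among the compounds shown, and "the series" means these compounds.

Measured in a functional assay on MDA-MB-468 cells (Homo sapiens) for antiproliferative activity, read by MTT assay, with a stated time of 72 h (a lower number here means a stronger inhibitor, a higher number a weaker inhibitor), the compounds give:

Compound 1 `COc1cc(-c2nccn2C)cc(OC)c1OC` gives > 100000 nM
Compound 2 `COc1cc(-c2nccn2C(C)C)cc(OC)c1OC` gives > 100000 nM
Compound 3 `COc1cc(-c2nccn2S(=O)(=O)c2ccccc2)cc(OC)c1OC` gives > 100000 nM

Each of these entries is a limit of the assay and not a number. The whole record so far is the limit of > 100000 nM in this assay, at which 3 of the 3 values shown sit. Compound 2 therefore has only a limit, > 100000 nM, and no exact place in the series.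

Compound 4 `COc1cc(-c2nccn2Cc2ccccc2)cc(OC)c1OC` alters one group of compound 2, with benzyl in place of isopropyl on an aromatic nitrogen. Among the measured compounds shown here, the one measured step that also swaps the group on this nitrogen is a step that the two limits leave unreadable from compound 1 to compound 2, so it offers no size to carry over. Compound 3 also has a six-membered aromatic ring in the group on its nitrogen, and it gives the limit > 100000 nM.

No clear change is therefore expected in this assay, and another limit is the likeliest result. The estimated step is a number no higher from compound 2 to compound 4 (the limit leaves the size open). For compound 4 the estimated value is 100000 nM, with an expected range from 30000 nM to 200000 nM.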

Compound 4, half-maximal inhibitory concentration: > 100000 nM
Compound 4 was reported as a limit (the forecaster's own chance of this, stated with the estimate: 70%); the middle value sits exactly at the limit.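

No new step can be read from compound 1 or compound 2 to compound 4, since each result in this assay is a limit and not a number: the limit of > 100000 nM in this assay, at which 4 of the 4 values shown sit.

The compounds shown leave open whether changing the group on this aromatic nitrogen affects activity at all.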